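Adding chlorine and methyl to the distal ring

This account rests on a few compounds, and the source may have more. Where it says the series, first, only, none or still open, it means among the compounds named here.

Compound 3 `O=C(O)COc1ccc(NCc2cccc(-c3ccccc3)c2)cc1F` gives 58.5 nM in a functional assay on CHO cells for agonist activity at Free fatty acid receptor 1 (Homo sapiens), read by FLIPR and calcium flux (a higher number here means that more compound is needed for the effect, a lower number that less compound is needed), the highest of the three numbers measured. Compound 2 `COCCOc1cc(C)c(-c2cccc(CNc3ccc(OCC(=O)O)c(F)c3)c2)c(C)c1` gives 51.6 nM, within the scatter of compound 3, while compound 1 `CCOc1cc(C)c(-c2cccc(CNc3ccc(OCC(=O)O)c(F)c3)c2)c(C)c1` gives 24.2 nM, beyond the scatter below compound 3. Compound 4 `Cc1ccc(-c2cccc(CNc3ccc(OCC(=O)O)c(F)c3)c2)c(Cl)c1` differs from compound 3 by 2-chloro-4-methylphenyl in place of phenyl on an aromatic carbon. Among the measured compounds shown here, no measured step touches this ring directly: the only measured step, a 2.1-fold higher number from compound 1 to compound 2 (0.33 log units; beyond the scatter), concerns the chain on the same distal ring. Since compound 1 and compound 2, which both carry a substituted distal ring, give lower numbers than compound 3, a modest drop toward lower numbers is expected, a 2.3-fold lower number from compound 3 to compound 4 (0.37 log units; beyond the scatter). Compound 4 is estimated at 25 nM, with a range from 8 nM to 80 nM.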

Compound 4, half-maximal effective concentration: 22.5 nM
For compound 4 the middle estimate is 1.1-fold (0.05 log units) above the measured one, and the stated range covers the measured number.
By their numbers in this assay, from the lowest: compounds 4 and 1 (each within the scatter of the next); then compounds 2 and 3 (each within the scatter of the next).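

In this assay, among the compounds shown here, 2-chloro-4-methylphenyl in place of phenyl gives a 2.6-fold lower number from compound 3 to compound 4 (0.41 log units; beyond the scatter), the first direct reading of a change to this ring itself. At this aromatic carbon, then, a ring carrying two added groups lowers the number, so less compound is needed for the effect. Nothing measured here explains the step.

Whether the chlorine, the methyl or the two together account for the step stays open. So does what an amine or a nitrile on this ring would do.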